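Furan for hydroxyphenyl on the thiosemicarbazone side chain

The compounds below may be only part of what the source reports. "The series", "measured", "known", "first", "only" and "open" are said of these compounds alone.

Compound 1 `CC1=CC[C@H](C(C)(C)NC(=S)N/N=C/c2ccccc2O)CC1` gives 10800 nM in a functional assay on UACC-62 cells (Homo sapiens) for inhibition, read by sulforhodamine B assay, with a stated time of 48 h (on this read-out higher numbers stand for weaker inhibition of growth and lower numbers for stronger inhibition of growth), the lower of the two numbers recorded in the series. Compound 2 `CC1=CC[C@H](C(C)(C)NC(=S)N/N=C/c2ccccc2[N+](=O)[O-])CC1` gives 92200 nM in this assay, and the step of an 8.5-fold higher number from compound 1 to compound 2 (0.93 log units; beyond the scatter) lies beyond the scatter. Compound 3 `CC1=CC[C@H](C(C)(C)NC(=S)N/N=C/c2cccc([N+](=O)[O-])c2)CC1` gives > 100000 nM in this assay, which is a limit of the assay and not a number (the limit of > 100000 nM in this assay, at which 1 of the 3 values shown sits). Compound 4 `CC1=CC[C@H](C(C)(C)NC(=S)N/N=C/c2ccco2)CC1` has not yet been measured; it differs from compound 1 by furan-2-yl in place of 2-hydroxyphenyl on a carbon with a double bond to nitrogen. Among the compounds with values here, the one measured step that bears on this change also removes the hydroxy, namely an 8.5-fold higher number from compound 1 to compound 2 (0.93 log units; beyond the scatter), so a higher number, of modest size, is expected for compound 4 in this assay. Compound 4 is estimated at 30000 nM, with a range from 8000 nM to 100000 nM. The expected step is a 2.8-fold higher number from compound 1 to compound 4 (0.44 log units; beyond the scatter).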

Compound 4, concentration for total growth inhibition: 14100 nM
Estimate against measurement, compound 4: 2.1-fold (0.33 log units) above; low and high end bracket the measured number.
By their numbers in this assay, from the lowest: compounds 1 and 4 (each within the scatter of the next); then compound 2. At a limit, above all of these: compound 3.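

In this assay, furan-2-yl in place of 2-hydroxyphenyl on a carbon with a double bond to nitrogen gives a 1.3-fold higher number from compound 1 to compound 4 (0.12 log units; within the scatter), so this position tolerates a five-membered aromatic ring with 1 hetero atom. Compound 4 has no hydrogen-bond donor in this group, so losing the hydroxy does not by itself bring the higher number seen with compound 2. No measurement shown gives a reason for this result.

As far as these compounds go, whether an aminomethyl or carboxylic acid group on the furan ring would keep this level remains open. So does whether a thiophene or pyridine ring would serve as well as furan.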